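This account rests on a few compounds, and the source may have more. Where it says the series, first, only, none or still open, it means among the compounds named here.

Measured so far in an ADME assay on MT4 cells (Homo sapiens) for cytotoxicity, read by MTT assay; on this read-out lower numbers stand for higher toxicity in this test and higher numbers for lower toxicity in this test:

Compound 1 `O=C(CSc1nccn1-c1ccc(Cl)cc1)Nc1ccccc1F` gives > 345000 nM in this assay, a value that is a limit of the assay rather than a number.
Compound 2 `O=C(CSc1nccn1-c1ccc(Cl)cc1)Nc1ccccc1Br` gives > 300000 nM in this assay, again a limit of the assay rather than a number.
Among the measured compounds shown here, compound 3 `Cc1ccc(-n2ccnc2SCC(=O)Nc2ccccc2F)cc1` gives 37900 nM in this assay, the only number among the three.

Compounds 1 and 2 share one core and differ only in bromo in place of fluoro on an aromatic carbon. The step between them, a step that the two limits leave unreadable from compound 1 to compound 2, cannot be read because compound 1 sits at the limit of > 345000 nM in this assay, at which 1 of the 3 values shown sits, and compound 2 sits at the limit of > 300000 nM in this assay, at which 1 of the 3 values shown sits. For the measured compounds named here, compound 3 carries a different core: it differs from compound 1 in methyl in place of chloro on an aromatic carbon, and that change gave an at least 9.1-fold lower number from compound 1 to compound 3 (0.95 log units; beyond the scatter), so compound 3 is the one compound here for which this assay reports a number.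

Compound 4 `Cc1ccc(-n2ccnc2SCC(=O)Nc2ccccc2Br)cc1` has not been measured. It differs from compound 3 in bromo in place of fluoro on an aromatic carbon, the same change as from compound 1 to compound 2, made on the core of compound 3, and at the same place. The measured example of this change cannot be read, as said above. The expectation for compound 4 therefore rests mainly on compound 3 and its value 37900 nM. The step from compound 3 to compound 4 in this assay is expected to be a 1.1-fold lower number from compound 3 to compound 4 (0.03 log units; within the scatter), within the usual scatter. Compound 4 is therefore estimated at 35000 nM, with a likely range from 12000 nM to 100000 nM.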

Compound 4, half-maximal cytotoxic concentration: 39300 nM
For compound 4 the middle estimate is 1.1-fold (0.05 log units) below the measured one; the measured number falls inside the stated range.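

The measured step for bromo in place of fluoro on this core is a 1.0-fold higher number from compound 3 to compound 4 (0.02 log units; within the scatter), so here the two halogens give values that cannot be told apart in this assay. On the core of compound 1 the same change cannot be read, since both values there are limits of the assay and not numbers, so this pair does not show that the result carries from one core to the other. The other change, methyl in place of chloro, gave an at least 7.6-fold lower number from compound 2 to compound 4 (0.88 log units; beyond the scatter), so it lowers the number with bromo as well as with fluoro on the second aromatic ring, which shows a shared direction but not a shared size: the same change on two cores in this assay, an at least 9.1-fold lower number (0.95 log units; beyond the scatter) from compound 1 to compound 3 and an at least 7.6-fold lower number (0.88 log units; beyond the scatter) from compound 2 to compound 4; the limit leaves it open whether they differ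

The compounds shown carry only fluoro or bromo on one aromatic ring and only chloro or methyl on the other, so they leave open how far the number would move with a methoxy group, an amine or a longer chain in place of the methyl. They also leave open how far above the limits the true values of compound 1 and compound 2 lie, and with that how large the drop on replacing chloro with methyl really is.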